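A Side-Ring Swap on a Shared Enone Core

The source may hold more compounds than are shown below. What is called first, only, known or untested is meant among the compounds shown, and "the series" means these compounds.

Measured compounds:
compound 1 `O=C(O)c1ccc(C(=O)/C(=C\c2ccc(F)c([N+](=O)[O-])c2)SCc2ccc(Cl)cc2)cc1`: 50000 nM
compound 2 `O=C(/C(=C\c1ccc(O)cc1)S(=O)(=O)Cc1ccc(Cl)c(Cl)c1)c1ccc(Cl)cc1`: 10000 nM
compound 3 `Nc1c(Br)cc(Br)cc1/C=C(\C(=O)c1ccc(Br)cc1)S(=O)(=O)c1ccc(Br)cc1`: 25000 nM

All three were tested in a functional assay on DU-145 cells (Homo sapiens) for inhibition, read by trypan blue exclusion, with a stated time of 96 h; a higher number here means a weaker inhibitor of growth, a lower number a stronger inhibitor of growth. Compound 3 gives 25000 nM, the second highest of the three numbers. Compound 1 gives 50000 nM, a number that sits within the usual scatter of compound 3's, so the two cannot be told apart. Compound 2 gives 10000 nM, which is lower than compound 3 and lies beyond the scatter, so compound 2 is the clearer growth inhibitor of the pair.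

Compound 4 `O=C(/C(=C\c1ccc(Br)c([N+](=O)[O-])c1)S(=O)(=O)c1ccc(Br)cc1)c1ccc(Br)cc1` has not yet been measured. Compared with compound 3, the change is 4-bromo-3-nitrophenyl in place of 2-amino-3,5-dibromophenyl on a double-bonded chain carbon bound to a double-bonded chain carbon. Within the data shown here, no measured pair in this set shows this same change, so there is no direct precedent to lean on. Given that compound 1 also carries a nitro-bearing ring and gives 50000 nM, the step from compound 3 to compound 4 is expected to be small, with no clear direction beyond the scatter. The step of a 1.2-fold higher number from compound 3 to compound 4 (0.08 log units; within the scatter) is therefore estimated to stay within the usual scatter. Compound 4 is expected to give about 30000 nM, with a likely range from 10000 nM to 90000 nM.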

Compound 4, concentration for 50% growth inhibition: 10000 nM
Estimate against measurement, compound 4: 3.0-fold (0.48 log units) above; low and high end bracket the measured number.
By their numbers in this assay, from the lowest: compounds 2 and 4 (each within the scatter of the next); then compounds 3 and 1 (each within the scatter of the next).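

In this assay, among these compounds, putting 4-bromo-3-nitrophenyl in place of 2-amino-3,5-dibromophenyl on a double-bonded chain carbon bound to a double-bonded chain carbon gives a 2.5-fold lower number from compound 3 to compound 4 (0.40 log units; beyond the scatter), the only step in this set where just one place differs. It shows that the ring at this place can shift the growth-inhibition number beyond the scatter while the rest of the core stays fixed, though the step is modest. The swap removes the amino group, adds the nitro group and leaves one bromine fewer, and nothing available explains the shift or ties it to any one of these differences.

On these data alone, how much of the step belongs to each of these groups remains open. So does what a ring carrying a methoxy group or a nitrile would give at this place.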